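The source may report more compounds than this note shows. Statements on the series, on what has been measured and on what is new or still open speak of the compounds shown alone.

In a functional assay on the whole organism (strain Kunming) with Mus musculus as the target, with a stated time of 0.5 h (a higher number here means that more compound is needed for the effect, a lower number that less compound is needed), compound 1 `COc1cc(OC)c(OC)cc1/C=C/COC(=O)/C=C/c1cc(OC)c(OC)c(OC)c1OC` gives 155 mg/kg, compound 2 `COc1cc(OC)c(OC)cc1/C=C/COC(=O)/C=C/c1ccc(Br)cc1` gives 193 mg/kg and compound 3 `COc1cc(OC)c(OC)cc1/C=C/COC(=O)/C=C/c1ccc(OC)c(OC)c1OC` gives 203 mg/kg. Compound 2 therefore stands within the scatter of both other compounds. Compound 4 `COc1cccc(/C=C/C(=O)OC/C=C/c2cc(OC)c(OC)cc2OC)c1` departs from compound 2 by one change: 3-methoxyphenyl in place of 4-bromophenyl on a double-bonded chain carbon bound to a double-bonded chain carbon. Within the data shown here, only one measured step bears on this change, and only loosely, since no measured compound carries the 3-methoxyphenyl group: hydrogen in place of methoxy on an aromatic carbon gave a 1.3-fold higher number from compound 1 to compound 3 (0.12 log units; within the scatter). The three measured compounds differ at this same place yet remain within the scatter of one another, so no step beyond the scatter is expected in this assay. The estimated step is a 1.0-fold lower number from compound 2 to compound 4 (0.01 log units; within the scatter). Compound 4 is expected at 190 mg/kg, with an estimated range of 110 mg/kg to 330 mg/kg.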

Compound 4, dose for half-maximal effect: 247 mg/kg
The estimate for compound 4 lay 1.3-fold (0.11 log units) below the measured number; low and high end bracket the measured number.
By their numbers in this assay, from the lowest: compounds 1, 2, 3 and 4 (each within the scatter of the next).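

In this assay, 3-methoxyphenyl in place of 4-bromophenyl on a double-bonded chain carbon bound to a double-bonded chain carbon gives a 1.3-fold higher number from compound 2 to compound 4 (0.11 log units; within the scatter) and so lies within the scatter. This is the first listed step at this place that exchanges the whole aromatic group rather than removing one methoxy, and it adds one hydrogen-bond acceptor without moving the number beyond the scatter. No measured evidence accounts for this result. Going by these compounds, whether an amine or a carboxylic acid on this aromatic group would give a step beyond the scatter remains open.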